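This account rests on a few compounds, and the source may have more. Where it says the series, first, only, none or still open, it means among the compounds named here.

In a functional assay on NCI-H460 cells (Homo sapiens) for cytotoxicity (on this read-out lower numbers stand for stronger inhibition and higher numbers for weaker inhibition), three compounds sharing one core have been measured. Compound 1 `COc1ccc(S(=O)(=O)N2CCc3cccc(NC(=O)c4ccc([N+](=O)[O-])cc4)c32)cc1` gives 122 nM and compound 2 `COc1ccc(S(=O)(=O)N2CCc3cccc(NC(=O)c4ccc(F)cc4)c32)cc1` gives 95 nM, and the exchange of nitro for fluoro stays within the scatter, a 1.3-fold lower number from compound 1 to compound 2 (0.11 log units; within the scatter). Compound 3 `COc1ccc(S(=O)(=O)N2CCc3cccc(NC(=O)c4ccncc4)c32)cc1` gives 9.4 nM, the lowest number of the three and so the strongest inhibition.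

Compound 4 `COc1ccc(S(=O)(=O)N2CCc3cccc(NC(C)=O)c32)cc1` differs from compound 3 in one place, with methyl in place of pyridin-4-yl on a carbonyl carbon. Among the compounds with values here, the steps that bear on this change act at the same carbonyl carbon: a 13-fold lower number from compound 1 to compound 3 (1.11 log units; beyond the scatter) and a 10-fold lower number from compound 2 to compound 3 (1.00 log units; beyond the scatter), both beyond the scatter. They show that this position responds strongly to the group it carries, but each exchanges one aromatic ring for another, so none shows what methyl does there. With compound 3 at 9.4 nM, the best of the series, a move toward a higher number is expected, at least as large as those steps: the estimated change is a 27-fold higher number from compound 3 to compound 4 (1.42 log units; beyond the scatter). Compound 4 is estimated at 250 nM, within a range of 40 nM to 1800 nM.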

Compound 4, half-maximal inhibitory concentration: 75 nM
The estimate for compound 4 lay 3.3-fold (0.52 log units) above the measured number, within the range that was stated.
By their numbers in this assay, from the lowest: compound 3; then compounds 4, 2 and 1 (each within the scatter of the next).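

In this assay, the step to methyl, an 8.0-fold higher number from compound 3 to compound 4 (0.90 log units; beyond the scatter), shows that compound 3 stands apart from a group with no ring at all, which the exchanges between aromatic rings could not show. The other two steps, a 1.3-fold lower number from compound 2 to compound 4 (0.10 log units; within the scatter) and a 1.6-fold lower number from compound 1 to compound 4 (0.21 log units; within the scatter), both lie within the scatter, so the 4-fluorophenyl and 4-nitrophenyl rings of compound 2 and compound 1 give no measurable gain over methyl, and among these four compounds only pyridin-4-yl does. No measurement at hand explains why this one ring differs from the others.

The compounds shown leave open whether a plain phenyl or a saturated piperidine ring on this carbonyl carbon would behave like pyridin-4-yl or like methyl. They also leave open what a longer chain, such as propyl, or a chain ending in an amine would do there.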